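The compounds below may be only part of what the source reports. "The series", "measured", "known", "first", "only" and "open" are said of these compounds alone.

Compound 1 `Nc1scc(CN2CCN(c3ccc(Cl)c(C(F)(F)F)c3)CC2)c1C(=O)c1ccc(Cl)cc1` gives 3%.
Compound 2 `Nc1scc(CN2CCC(c3ccc(Cl)cc3)CC2)c1C(=O)c1ccc(Cl)cc1` gives 6%.
Compound 3 `Nc1scc(CN2CCN(c3cccc(F)c3)CC2)c1C(=O)c1cccc(C(F)(F)F)c1` gives 0%.

These three numbers come from an assay on CHO cells for displacement of a labelled ligand from adenosine receptor A3 (Homo sapiens), read by scintillation counting, with a stated time of 120 min, tested at 10 uM; on this read-out lower numbers stand for less inhibition and higher numbers for more inhibition at the one concentration tested (going by the name of the read-out). All three are small, and the gaps among them stay within the usual scatter of repeated measurements, so compound 1 cannot be set apart from compound 2 or from compound 3 on these numbers: each of the three shows little inhibition at the one concentration tested.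

Compound 4 `Nc1scc(CN2CCN(c3c(F)cccc3F)CC2)c1C(=O)c1ccc(Cl)cc1` has not yet been measured. It differs from compound 1 in one place: 2,6-difluorophenyl in place of 4-chloro-3-(trifluoromethyl)phenyl on an amine nitrogen in a ring. The rest of the shared core, with its aminothiophene, its piperazine linked through a methylene, and its chlorophenyl carbonyl, stays as it is in compound 1.

Going by the values given here, no pair of measured compounds that differ in only one place has been measured, so there is no step on record to lean on. What the data do show is that three compounds built on the same core, with different aryl groups on the ring nitrogen, all sit at low inhibition. On that basis compound 4 is expected to behave the same way, with a step from compound 1 of a number 1 percentage points higher from compound 1 to compound 4 (within the scatter), none beyond the scatter. In this assay compound 4 is estimated at 4%, in a range from 0% to 15%.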

Compound 4, a percentage reported as inhibition, at one concentration (the size of the read-out at that concentration, not a potency): 4%
Beside the measured number, compound 4's estimate shows no gap at the digits printed; the range from low to high includes it.
By their numbers in this assay, from the lowest: compounds 3, 1, 4 and 2 (each within the scatter of the next).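

In this assay, going by these compounds alone, putting 2,6-difluorophenyl in place of 4-chloro-3-(trifluoromethyl)phenyl on the amine nitrogen in the ring gives a number 1 percentage points higher from compound 1 to compound 4 (within the scatter), and this is the first direct comparison of two compounds that differ in one place only. The group that leaves has 11 heavy atoms, including chlorine and three fluorines, while the group that enters has 8, including two fluorines, so this aryl position accepts a change in size and substitution without a measurable shift in this read-out, and inhibition stays small at the one concentration tested. No independent measurement on record bears on why the number holds steady.

From the compounds shown here alone, all the groups on this nitrogen so far are aryl groups, so it remains open whether something of another kind, such as a benzyl group, an acetyl group or a longer chain ending in a carboxylic acid, would lift inhibition clear of these small numbers. Going by these compounds, it is also open whether a change elsewhere on the shared core, such as an amide in place of the free amine, would do so.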